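From methylsulfonyl to cyclopentylcarbonyl on compound 2

A few compounds are considered here, and "the series" means these few. Any claim that something is new, unique, unknown or untested is made for them only; others in the source may bear on it.

Three related compounds have been measured so far in a physicochemical assay for lipophilicity, at pH 7.4 (on this read-out higher numbers stand for higher lipophilicity and lower numbers for lower lipophilicity), and they spread widely. Compound 2 (`CCc1ccc(N(CC(C)C)S(=O)(=O)c2ccc3c(c2)C(O)CC(C2CCN(S(C)(=O)=O)CC2)O3)cc1`) gives 3.22 and stands second highest of the three. Compound 1 (`O=S(=O)(c1ccc2c(c1)C(O)CC(C1CCOCC1)O2)N1CCC(c2ccccc2)CC1`) gives 2.63 and lies below it beyond the scatter, while compound 3 (`CCc1ccc(N(CC(C)C)S(=O)(=O)c2ccc3c(c2)C(C)CC(C2CCOCC2)O3)cc1`) gives 5.71 and lies above it beyond the scatter.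

Compound 4 (`CCc1ccc(N(CC(C)C)S(=O)(=O)c2ccc3c(c2)C(O)CC(C2CCN(C(=O)C4CCCC4)CC2)O3)cc1`) carries cyclopentylcarbonyl in place of methylsulfonyl on an amine nitrogen in a ring and is otherwise compound 2. Among the compounds with values here, no measured pair isolates this change, and compound 1 and compound 3 each differ from compound 2 in more than one place. The expectation therefore starts from compound 2 at 3.22 and rests on the structural change alone, with a five-membered non-aromatic ring of carbon only entering. An upward step beyond the scatter is expected in this assay and is estimated as a number 0.88 log units higher from compound 2 to compound 4 (beyond the scatter) in size. For compound 4 the estimated value is 4.1 with an expected range from 3.5 to 4.7 in this measurement.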

Compound 4, distribution coefficient: 5.04
Compound 4: middle estimate off by 0.94 log units, on the low side; measured number above the stated range.
By their numbers in this assay, from the lowest: compound 1; then compound 2; then compound 4; then compound 3.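

In this assay, replacing methylsulfonyl with cyclopentylcarbonyl on an amine nitrogen in a ring gives a number 1.82 log units higher from compound 2 to compound 4 (beyond the scatter), and this large step is tied to a single place in the structure. Within the data shown here, none of the earlier compounds could show this, as no two of them differed in only one place. No independent measurement is available to account for the size of the step.

The compounds shown leave open how much of the step goes with exchanging the sulfonyl for a carbonyl and how much with the entering five-membered ring of carbon only; an acetyl group or a cyclopentylsulfonyl group on the same nitrogen would separate the two. Going by these compounds, it also remains open whether the same exchange would give a step of similar size on the core of compound 1 or compound 3.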